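This account rests on a few compounds, and the source may have more. Where it says the series, first, only, none or still open, it means among the compounds named here.

Working notes on the series.

Two compounds have numbers in an assay on HeLa cells for displacement of a labelled ligand from adenosine receptor A3 (Homo sapiens), read by scintillation counting, with a stated time of 180 min, tested at 10 uM; on this read-out higher numbers stand for more inhibition at the one concentration tested (going by the name of the read-out) and lower numbers for less inhibition. Compound 1 `N=c1oc2ccc(Br)cc2cc1C(=O)NC1CCCCC1` gives 8% in this assay. Compound 2 `COc1cccc2cc(C(=O)NC(CO)(CO)CO)c(=N)oc12` gives 18% in this assay. On these two numbers compound 1 stands as the smaller of the pair, but its gap to compound 2 lies within the usual scatter of repeated measurements, so the two compounds cannot be told apart on this read-out; both numbers are low at the single concentration tested. Going by the values given here, no step between measured compounds that differ in one place is available, so nothing measured yet shows how a change on the amide-type nitrogen moves the read-out.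

Compound 3 `N=c1oc2ccc(Br)cc2cc1C(=O)NCCCO` has not been measured. It differs from compound 1 in one place: 3-hydroxypropyl in place of cyclohexyl on an amide-type nitrogen. Among the compounds with values here, with both measured compounds reading low and no measured step on which to rest a direction, the expected step from compound 1 to compound 3 in this assay is a number 2 percentage points higher from compound 1 to compound 3 (within the scatter), that is, none beyond the scatter. Compound 3 is therefore estimated at 10% in this assay, within a range from 0% to 28%.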

Compound 3, a percentage reported as inhibition, at one concentration (the size of the read-out at that concentration, not a potency): 17%
Compound 3: the middle estimate sits 7 percentage points below what was measured; the measured number falls inside the stated range.
By their numbers in this assay, from the lowest: compounds 1, 3 and 2 (each within the scatter of the next).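

Going by these compounds alone, the first measured change on this amide-type nitrogen, 3-hydroxypropyl in place of cyclohexyl on the core of compound 1, gives in this assay a number 9 percentage points higher from compound 1 to compound 3 (within the scatter). Compound 1 and compound 3 therefore cannot be told apart on this read-out, even though the change takes away a six-membered non-aromatic ring of carbon only and brings in a chain with a hydrogen-bond donor and a hydrogen-bond acceptor, so at the one concentration tested neither the ring nor the hydroxyl-bearing chain is shown to matter at this position. Nothing available bears on why these two compounds read alike.

Still open, as far as these compounds go, is whether another group on this nitrogen, such as a chain ending in an amine, a chain ending in a carboxylic acid, a longer hydroxyalkyl chain or a phenyl ring, would give a step beyond the scatter. Within the data shown here, also open is whether compound 1 and compound 3 would remain indistinguishable at another concentration, as a reading at one concentration gives no potency for either compound.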